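Swapping a Saturated Side Chain for an Aromatic Ring

A few compounds are considered here, and "the series" means these few. Any claim that something is new, unique, unknown or untested is made for them only; others in the source may bear on it.

Among the measured compounds shown here, compound 1 `Cc1cc(C)c(CN2CCc3c(Cl)cc([C@H](CO)[C@H]4CCCO4)c(Cl)c3C2=O)c(=O)[nH]1` is the only compound here with a single number in an assay for inhibition of histone-lysine N-methyltransferase EZH2 variant Y641N (Homo sapiens), read by scintillation counting, with a stated time of 60 min, in the presence of a further agent that is not named here (on this read-out higher numbers stand for weaker inhibition and lower numbers for stronger inhibition), where compound 1 gives 8 nM. Compound 2 `COC(c1cc(Cl)c2c(c1Cl)C(=O)N(Cc1c(C)cc(C)[nH]c1=O)CC2)C1CCN(C(=O)CO)CC1` carries two entries in this assay: compound 2 gives 70 nM; 0.25 nM (2 entries), and the several entries of compound 2 in this assay, 70 nM; 0.25 nM (2 entries) shows how far repeated entries of one compound can lie apart. Compound 3 `Cc1cc(C)c(CN2CCc3c(Cl)cc(-c4c(C)noc4C)c(Cl)c3C2=O)c(=O)[nH]1` has not yet been measured. It differs from compound 1 in one place: a group of 7 heavy atoms (5 carbon, 1 nitrogen, 1 oxygen; one five-membered aromatic ring with 2 hetero atoms) in place of a group of 8 heavy atoms (6 carbon, 2 oxygen; one five-membered non-aromatic ring with 1 hetero atom), on an aromatic carbon. For the measured compounds named here, no measured pair of this kind is available, so the expectation rests on the size of the change and on the spread seen for compound 2 in the several entries of compound 2 in this assay, 70 nM; 0.25 nM (2 entries). The expected step is a 3.8-fold higher number from compound 1 to compound 3 (0.57 log units; beyond the scatter), a loss of strength somewhat beyond the scatter but not a large one. Compound 3 is therefore expected to give 30 nM in this assay, with a range from 5 nM to 200 nM.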

Compound 3, inhibition constant: 1.15 nM
Beside the measured number, compound 3's estimate is 26-fold (1.42 log units) above it, and the stated range ends above it.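

In this assay, replacing the side chain that carries a five-membered non-aromatic ring with 3,5-dimethyl-1,2-oxazol-4-yl gives a 7.0-fold lower number from compound 1 to compound 3 (0.84 log units; beyond the scatter). This aromatic carbon therefore accepts an aromatic ring without loss of strength. In this pair, strength does not depend on the hydrogen-bond donor or the two defined stereocentres of the group that leaves, although a single step deserves caution, as repeated entries of one compound can lie far apart: the several entries of compound 2 in this assay, 70 nM; 0.25 nM (2 entries)

The compounds shown leave open whether the step comes from the aromatic ring itself or from its two methyl groups. A 1,2-oxazol-4-yl ring without methyl groups, or a phenyl ring on the same carbon, would help separate these two possibilities.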